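This account rests on a few compounds, and the source may have more. Where it says the series, first, only, none or still open, it means among the compounds named here.

Compound 1, `Cc1ccc(/C=C2\CCCC(CN(C)c3ccc(C)cc3)C2=O)cc1`: in a functional assay on the whole organism (Ear, strain Kunming) for inhibition, with Mus musculus as the target, with stated times of 1 h and 30 min, at a dose of 200 mg/kg by the oral route (a higher number here means more inhibition at the dose given (going by the name of the read-out), a lower number less inhibition), compound 1 gives 27.6%.
Compound 2, `Cc1ccc(/C=C2\CCCC(CN(C)c3cccc(C)c3)C2=O)cc1`: compound 2 gives 35.4%.
Compound 3, `Cc1ccc(N(C)CC2CCC/C(=C\c3ccccc3)C2(O)c2ccccc2)cc1`: compound 3 gives 66.7%.

Compounds 1 and 2 share one core and differ in a single place: 3-methylphenyl in place of 4-methylphenyl on an amine nitrogen. That change made a step of a number 7.8 percentage points higher from compound 1 to compound 2 (within the scatter). Compound 3 is built on a different core; the difference between the two cores is not broken down here. Among the three measured compounds, compound 3 gives the largest number, and its distance from each of the other two is beyond the usual scatter.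

Compound 4, `Cc1cccc(N(C)CC2CCC/C(=C\c3ccccc3)C2(O)c2ccccc2)c1`, has not yet been measured. It differs from compound 3 by 3-methylphenyl in place of 4-methylphenyl on an amine nitrogen, at the same kind of place as the earlier change, so it is the same change carried onto the core of compound 3. From compound 3 to compound 4 a small step is expected, a number 3.3 percentage points higher from compound 3 to compound 4 (within the scatter), resting on the earlier step of a number 7.8 percentage points higher from compound 1 to compound 2 (within the scatter), which stayed within the scatter; whether the change behaves alike on the second core is not known from these data. Compound 4 is therefore expected to give about 70% in this assay, with a likely range from 55% to 85%.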

Compound 4, a percentage reported as inhibition, in the whole organism at one dose (the size of the read-out at that dose, not a potency): 23.1%
The estimate for compound 4 lay 46.9 percentage points above the measured number; the whole stated range lies above it.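

Putting 3-methylphenyl in place of 4-methylphenyl on an amine nitrogen gave a step of a number 43.6 percentage points lower from compound 3 to compound 4 (beyond the scatter) in this assay. Going by these compounds alone, the same change therefore did not carry over from one core to the other in these compounds: the same change on two cores in this assay, a number 7.8 percentage points higher (within the scatter) from compound 1 to compound 2 and a number 43.6 percentage points lower (beyond the scatter) from compound 3 to compound 4, 51.4 percentage points apart, beyond the scatter of two such steps This shows that, within this small set, the outcome of the change depends on the core it sits on, so a step seen on one core cannot safely be used to estimate a step on the other; it does not show which part of the cores makes the difference, why the steps differ, or how the change would behave on any further core, since only one pair on each of two cores is available, each tested at a single dose.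

The compounds shown leave open how each core would respond to a plain phenyl group on the amine nitrogen. They also leave open what an ethyl group in place of the methyl on that nitrogen would do on either core.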